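The source may hold more compounds than are shown below. What is called first, only, known or untested is meant among the compounds shown, and "the series" means these compounds.

Measured in a functional assay on HepG2 cells (Homo sapiens) for cytotoxicity, read by MTT assay, with a stated time of 48 h; a higher number here means a weaker inhibitor, a lower number a stronger inhibitor:
Compound 1 `COc1ccc(/C=N/NC(=O)CSc2nnc(-c3ccncc3)o2)cc1`: 15800 nM
Compound 2 `O=C(CSc1nnc(-c2ccncc2)o1)N/N=C/c1cc(Cl)ccc1O`: 3970 nM
Compound 3 `O=C(CSc1nnc(-c2ccncc2)o1)N/N=C/c1cc(Br)ccc1O`: 6490 nM

Compound 3 stands with compound 2 at the low end of these three numbers. The step of a 1.6-fold higher number from compound 2 to compound 3 (0.21 log units; within the scatter) lies within the scatter, whereas the step of a 2.4-fold lower number from compound 1 to compound 3 (0.39 log units; beyond the scatter) lies beyond it.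

The next compound, compound 4 `O=C(CSc1nnc(-c2ccncc2)o1)N/N=C/c1ccco1`, keeps the shared core and carries furan-2-yl in place of 5-bromo-2-hydroxyphenyl on a carbon with a double bond to nitrogen. Within the data shown here, no measured compound carries furan-2-yl, so any expectation rests on indirect evidence. The closest guides are the two other changes of the group at this place, a 4.0-fold lower number from compound 1 to compound 2 (0.60 log units; beyond the scatter) and a 2.4-fold lower number from compound 1 to compound 3 (0.39 log units; beyond the scatter). Both are modest, and both show the 4-methoxyphenyl compound with the higher number. Compound 4 also loses the 5-bromo-2-hydroxyphenyl group, so a modest upward step in this assay is expected, though the evidence for it is thin. The estimate amounts to an expected 2.2-fold higher number from compound 3 to compound 4 (0.33 log units; beyond the scatter). For compound 4 the expected value is 14000 nM, with an estimated range from 5000 nM to 40000 nM.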

Compound 4, half-maximal inhibitory concentration: 12500 nM
Compound 4: the middle estimate sits 1.1-fold (0.05 log units) above what was measured, and the stated range covers the measured number.
By their numbers in this assay, from the lowest: compounds 2, 3, 4 and 1 (each within the scatter of the next, the first and the last beyond it).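

In this assay furan-2-yl brings a five-membered aromatic ring to this place on a carbon with a double bond to nitrogen, and the number does not separate from either six-membered neighbour: the result shows a 1.9-fold higher number from compound 3 to compound 4 (0.28 log units; within the scatter) and also a 1.3-fold lower number from compound 1 to compound 4 (0.10 log units; within the scatter) and so stays close to both compounds, even though they differ from each other. Only the comparison with the 5-chloro-2-hydroxyphenyl group separates clearly, with a 3.1-fold higher number from compound 2 to compound 4 (0.50 log units; beyond the scatter) as a modest step, so at this place compound 2 alone holds a lead over the furan-2-yl compound, while compound 3 does not. Nothing available explains why these numbers fall as they do.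

The compounds shown leave open whether the hydroxy group or the halogen on the phenyl ring accounts for the lower number of compound 2, which a plain phenyl, a 2-hydroxyphenyl or a 3-chlorophenyl group could help to separate. As far as these compounds go, it also remains open how other groups at this place would behave, such as thiophen-2-yl, a saturated cyclohexyl ring, or a phenyl ring carrying an amine or a carboxylic acid.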